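The compounds below may be only part of what the source reports. "The series", "measured", "known", "first", "only" and "open" are said of these compounds alone.

In a functional assay on A2780 cells (Homo sapiens) for inhibition, read by WST assay, with a stated time of 72 h (on this read-out lower numbers stand for stronger inhibition and higher numbers for weaker inhibition), compound 1 `C[C@@H](CCCCCN/C(=N\C#N)Nc1ccncc1)C(=O)NOC1CCCCC1` gives 0.08 nM, while its stereoisomer compound 2 `C[C@H](CCCCCN/C(=N\C#N)Nc1ccncc1)C(=O)NOC1CCCCC1` gives 3.9 nM, the higher of the two numbers. The next structure, compound 3 `N#C/N=C(\NCCCCC[C@@H](Cc1ccccc1)C(=O)NOC1CCCCC1)Nc1ccncc1`, departs from compound 2 by phenyl in place of hydrogen on a saturated chain carbon, two bonds along the chain from a carbonyl carbon, which reads as methyl to benzyl. Among the measured compounds shown here, only one measured step bears on this change: a 49-fold higher number from compound 1 to compound 2 (1.69 log units; beyond the scatter), a large step due to the fact that compounds 1 and 2 differ only in the configuration as drawn. It shows that the stereocentre carrying this methyl matters, yet it involves no change of group, so it sets neither a size nor a direction for benzyl. No step beyond the scatter is therefore expected in this assay, though with wide uncertainty. Compound 3 is estimated at 5 nM, within a range of 0.5 nM to 50 nM. The expected change is a 1.3-fold higher number from compound 2 to compound 3 (0.11 log units; within the scatter).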

Compound 3, half-maximal inhibitory concentration: 0.32 nM
For compound 3 the middle estimate is 16-fold (1.19 log units) above the measured one, outside the stated range (below it).
By their numbers in this assay, from the lowest: compound 1; then compound 3; then compound 2.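

At this saturated chain carbon, two bonds along the chain from a carbonyl carbon, the change from methyl to benzyl has a clear effect: in this assay it gives a 12-fold lower number from compound 2 to compound 3 (1.09 log units; beyond the scatter). The position therefore accepts a phenyl in place of hydrogen, with its 6 heavy atoms, and the number falls rather than rises. The earlier step, a 49-fold higher number from compound 1 to compound 2 (1.69 log units; beyond the scatter), had spoken only to the stereocentre and not to any change of group: the fact that compounds 1 and 2 differ only in the configuration as drawn

As far as these compounds go, it remains open whether an ethyl, a cyclohexylmethyl or a longer chain at this carbon would lower the number in the same way, or whether the aromatic ring itself is needed. Also open, from the compounds shown here alone, is how a benzyl carrying a hydroxyl or an amine on its ring would read, and how benzyl behaves in the opposite configuration.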